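Exchanging One Substituted Phenyl Group on the Shared Core

The source may report more compounds than this note shows. Statements on the series, on what has been measured and on what is new or still open speak of the compounds shown alone.

Of the compounds shown here, three have been measured so far in a functional assay on CNE-2 cells (Homo sapiens) for antiproliferative activity, read by sulforhodamine B assay, with a stated time of 48 h; on this read-out higher numbers stand for weaker inhibition and lower numbers for stronger inhibition. Compound 1 (`COc1ccc(C=C(C(=O)/C=C/c2cccc(OC)c2OC)C(=O)/C=C/c2cccc(OC)c2OC)cc1OC`) gives 280 nM. Compound 2 (`COc1ccc(/C=C/C(=O)C(=Cc2ccc(O)c(F)c2)C(=O)/C=C/c2ccc(OC)cc2OC)c(OC)c1`) gives 2830 nM, and compound 3 (`COc1ccc(/C=C/C(=O)C(=Cc2cc(Br)c(O)c(OC)c2)C(=O)/C=C/c2ccc(OC)cc2OC)c(OC)c1`) gives 1780 nM. Compound 3 therefore stands within the scatter of compound 2, while compound 1 has a clearly lower number than compound 3.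

The next compound to be read is compound 4 (`COc1ccc(/C=C/C(=O)C(=Cc2ccc(OC)c(O)c2)C(=O)/C=C/c2ccc(OC)cc2OC)c(OC)c1`). The change that leads to it is 3-hydroxy-4-methoxyphenyl in place of 3-bromo-4-hydroxy-5-methoxyphenyl on a double-bonded chain carbon bound to a double-bonded chain carbon. In words, 3-hydroxy-4-methoxyphenyl takes the place of 3-bromo-4-hydroxy-5-methoxyphenyl on a double-bonded chain carbon bound to a double-bonded chain carbon.

Going by the values given here, only one measured step touches this place: a 1.6-fold lower number from compound 2 to compound 3 (0.20 log units; within the scatter). That exchange, from 3-fluoro-4-hydroxyphenyl to the group now leaving, stayed within the scatter. Among the compounds with values here, compound 1 differs from the others in more than one place, so it offers no single step to go by. One step is thin evidence, and no direction can be drawn from it, so no change beyond the scatter is expected here. The expected step is a 1.1-fold higher number from compound 3 to compound 4 (0.05 log units; within the scatter). The estimate for compound 4 is 2000 nM, with an expected range from 800 nM to 5000 nM.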

Compound 4, half-maximal inhibitory concentration: 760 nM
The estimate for compound 4 lay 2.6-fold (0.42 log units) above the measured number; the whole stated range lies above it.
By their numbers in this assay, from the lowest: compound 1; then compound 4; then compounds 3 and 2 (each within the scatter of the next).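

In this assay, the position on a double-bonded chain carbon bound to a double-bonded chain carbon now responds to the exchange of its substituted phenyl group: 3-hydroxy-4-methoxyphenyl in place of 3-bromo-4-hydroxy-5-methoxyphenyl gives a 2.3-fold lower number from compound 3 to compound 4 (0.37 log units; beyond the scatter), and in place of 3-fluoro-4-hydroxyphenyl it gives a 3.7-fold lower number from compound 2 to compound 4 (0.57 log units; beyond the scatter). The only earlier step here, a 1.6-fold lower number from compound 2 to compound 3 (0.20 log units; within the scatter), had shown no separation between the two groups that carry a halogen, whereas the group with neither bromine nor fluorine now stands apart from both, with no exception among these three compounds. Nothing measured here bears on why the number moved.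

The new group differs from each departing group in more than one feature, since it has lost the halogen and its hydroxy and methoxy groups are named at different ring numbers, so the compounds shown cannot say which of these changes carries the step. From the compounds shown here alone, it also remains open whether an amine in place of the hydroxy group of 3-hydroxy-4-methoxyphenyl would hold, lose or extend this step.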